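Piperidine substituent swap in the oxazolyl ketone series

This account rests on a few compounds, and the source may have more. Where it says the series, first, only, none or still open, it means among the compounds named here.

Measured so far in an assay on isolated protein for inhibition of Fatty-acid amide hydrolase 1 (Homo sapiens); on this read-out lower numbers stand for stronger inhibition and higher numbers for weaker inhibition:
compound 1 `O=C(CCCC1CCN(C(=O)CC2CCCCC2)CC1)c1ncco1`: 100 nM
compound 2 `CC(C)C(=O)N1CCC(CCCC(=O)c2ncco2)CC1`: 250 nM

For the measured compounds named here, compound 2 holds the higher of the two numbers in this assay; its nearest neighbour is compound 1, and the only step recorded so far runs between them: a 2.5-fold higher number from compound 1 to compound 2 (0.40 log units; beyond the scatter), a change confined to the group on the carbonyl carbon attached to the ring nitrogen.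

Compound 3 `O=C(CCCC1CCN(Cc2ccccc2Cl)CC1)c1ncco1` is the next point and is not yet measured in this assay. Relative to compound 2 the change is 2-chlorobenzyl in place of isopropylcarbonyl on an amine nitrogen in a ring. Going by the values given here, only the step from compound 1 to compound 2 bears on this position, and it was modest; no measured pair removes the carbonyl from the ring nitrogen, so the effect of that part of the change is unknown. The step of a 1.3-fold lower number from compound 2 to compound 3 (0.10 log units; within the scatter) is therefore expected to be small, in either direction, and may well fall within the scatter. For compound 3 the expected value in this assay is 200 nM, with a range of 40 nM to 1000 nM.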

Compound 3, half-maximal inhibitory concentration: 260 nM
The estimate for compound 3 lay 1.3-fold (0.11 log units) below the measured number, and the stated range covers the measured number.
By their numbers in this assay, from the lowest: compound 1; then compounds 2 and 3 (each within the scatter of the next).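

In this assay the exchange of isopropylcarbonyl for 2-chlorobenzyl on the ring nitrogen gives a 1.0-fold higher number from compound 2 to compound 3 (0.02 log units; within the scatter) and so leaves the two compounds level, although the entering group has an aromatic ring and no carbonyl. The earlier step varied only the group on the carbonyl carbon and kept the carbonyl on the ring nitrogen; this pair shows that, at least for these two groups, the carbonyl can be absent from that nitrogen with the number staying within the scatter, while the whole group is exchanged at once, so the parts of the change cannot be separated. Nothing at hand explains why these two different groups read alike.

Still open, on these data alone, is what the chlorine and the aromatic ring each contribute, which an unsubstituted benzyl group or a 2-fluorobenzyl group on the same nitrogen would begin to separate. Also open, as far as these compounds go, is whether a cyclohexylmethyl group attached directly to that nitrogen, without the carbonyl, would read closer to compound 1 at 100 nM or to compound 3 at 260 nM.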